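Dimethylamino for phenoxy on the pendant aryl ring

The source may report more compounds than this note shows. Statements on the series, on what has been measured and on what is new or still open speak of the compounds shown alone.

Three analogues of a shared core have been measured in a functional assay on SR cells (Homo sapiens) for inhibition, read by sulforhodamine B assay, with a stated time of 48 h; on this read-out higher numbers stand for weaker inhibition of growth and lower numbers for stronger inhibition of growth. Compound 1 `COc1cc(C)cc(-c2c(-c3ccnc(-c4ccc(C(C)=O)cc4)c3)cnn2CC#N)c1` gives 2870 nM. Compound 2 `COc1cc(C)cc(-c2nn(CC#N)cc2-c2ccc(-c3cccc(C(C)=O)c3)nc2)c1` gives 1620 nM. Compound 3 `Cc1cc(O)cc(-c2nn(CC#N)cc2-c2ccnc(-c3ccc(Oc4ccccc4)cc3)c2)c1` gives 3770 nM; its number lies within the scatter of that of compound 1 and beyond the scatter above that of compound 2. Compound 4 `Cc1cc(O)cc(-c2nn(CC#N)cc2-c2ccnc(-c3ccc(N(C)C)cc3)c2)c1` differs from compound 3 by dimethylamino in place of phenoxy on an aromatic carbon. For the measured compounds named here, no measured pair shows this change, so the step from compound 3 to compound 4 in this assay is expected to be small, a 1.1-fold higher number from compound 3 to compound 4 (0.03 log units; within the scatter), with no direction beyond the scatter claimed. Compound 4 is thus estimated at 4000 nM, with a range from 1500 nM to 12000 nM.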

Compound 4, concentration for 50% growth inhibition: 2640 nM
Compound 4: the middle estimate sits 1.5-fold (0.18 log units) above what was measured, within the range that was stated.
By their numbers in this assay, from the lowest: compounds 2, 4, 1 and 3 (each within the scatter of the next, the first and the last beyond it).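

In this assay, dimethylamino in place of phenoxy, para to a large group, gives a 1.4-fold lower number from compound 3 to compound 4 (0.15 log units; within the scatter) and so does not move the number beyond the scatter. At this position, the six-membered aromatic ring of the phenoxy group can therefore leave without a change that this read-out can resolve. No available measurement gives a reason for this result.

On these data alone, whether morpholine, a carboxylic acid or a longer chain at this place would give a step beyond the scatter remains open. Also open, as far as these compounds go, is whether dimethylamino gives a similar step in other analogues of the series.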